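The compounds below may be only part of what the source reports. "The series", "measured", "known", "first", "only" and "open" are said of these compounds alone.

In a physicochemical assay for lipophilicity, at pH 7.4 (on this read-out lower numbers stand for lower lipophilicity and higher numbers for higher lipophilicity), the three measured compounds share one core. Compound 1 `CCc1ccc(N(CC(C)C)S(=O)(=O)c2ccc3c(c2)CCC(C2CCOCC2)O3)cc1` reads 5.38 and compound 2 `CCc1ccc(N(CC(C)C)S(=O)(=O)c2ccc3c(c2)C(OC)CC(C2CCOCC2)O3)cc1` reads 4.69 on this scale, while compound 3 `CCc1ccc(N(CC(C)C)S(=O)(=O)c2ccc3c(c2)C(N)CC(C2CCOCC2)O3)cc1` stands lowest of the three at 3.08 so far. The change to compound 4 `CCc1ccc(N(CC(C)C)S(=O)(=O)c2ccc3c(c2)C(OC2CCCCC2)CC(C2CCOCC2)O3)cc1` is cyclohexyloxy in place of amino on a saturated ring carbon and amounts to cyclohexyloxy in place of amino on a saturated ring carbon. Methoxy in place of hydrogen gave a number 0.69 log units lower from compound 1 to compound 2 (beyond the scatter) as a modest drop, amino in place of hydrogen gave a number 2.30 log units lower from compound 1 to compound 3 (beyond the scatter) as a large one, and amino in place of methoxy gave a number 1.61 log units lower from compound 2 to compound 3 (beyond the scatter) as another large one. Read in reverse, that last step a number 1.61 log units lower from compound 2 to compound 3 (beyond the scatter) points to a large rise on leaving amino for an ether, and cyclohexyloxy is a larger ether than methoxy. A large upward step a number 2.82 log units higher from compound 3 to compound 4 (beyond the scatter) is therefore expected in this assay on this reckoning. Compound 4 is estimated at 5.9 with an expected range of 5.2 to 6.6 on this scale.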

Compound 4, distribution coefficient: 6.28
Compound 4: the middle estimate sits 0.38 log units below what was measured, within the range that was stated.
By their numbers in this assay, from the lowest: compound 3; then compound 2; then compound 1; then compound 4.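

In this assay a substituent on this saturated ring carbon can also raise the number: cyclohexyloxy in place of hydrogen gives a number 0.90 log units higher from compound 1 to compound 4 (beyond the scatter) whereas methoxy and amino had both lowered it. The group on the ether oxygen thus decides on which side of the unsubstituted compound the value falls, with cyclohexyl in place of methyl giving a number 1.59 log units higher from compound 2 to compound 4 (beyond the scatter) and cyclohexyloxy in place of amino giving a number 3.20 log units higher from compound 3 to compound 4 (beyond the scatter) as the widest step at this position. Nothing shown gives a cause for these steps. Going by these compounds, whether an ethyl or isopropyl ether would fall between methoxy and cyclohexyloxy remains open, as does where a carboxylic acid on this carbon would read.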